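The source may report more compounds than this note shows. Statements on the series, on what has been measured and on what is new or still open speak of the compounds shown alone.

In a functional assay on CHO cells for activation of 5-hydroxytryptamine receptor 1D (Homo sapiens), read by GTPgammaS binding (a higher number here means a larger maximal response, a lower number a smaller maximal response), compound 1 `c1ccc(CNCC2CCN(CCCc3c[nH]c4ccc(-n5cnnc5)cc34)CC2)cc1` gives 101%, the highest of the three numbers here. Compound 2 `CN(Cc1ccsc1)C1CCN(CCCc2c[nH]c3ccc(-n4cnnc4)cc23)CC1` gives 93%, and compound 3 `C[C@@H](NC1CCN(CCCc2c[nH]c3ccc(-n4ccnc4)cc23)CC1)c1ccccc1` gives 65%. For the measured compounds named here, the only single-place step among them, a number 8 percentage points lower from compound 1 to compound 2 (within the scatter), exchanges the group on a saturated ring carbon and stays within the scatter. Compound 4 `CC(C)=CCN(C)C1CCN(CCCc2c[nH]c3ccc(-n4cnnc4)cc23)CC1` differs from compound 1 by methyl(3-methylbut-2-en-1-yl)amino in place of (benzylamino)methyl on a saturated ring carbon. That is the same kind of exchange as in the step to compound 2, so no change beyond the scatter is expected; compound 3 shows a lower number, but it differs in two places and cannot be read as a step. Compound 4 is therefore expected to give about 92%, likely between 72% and 105%. The expected step is a number 9 percentage points lower from compound 1 to compound 4 (within the scatter).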

Compound 4, largest response reached (reported as efficacy), in percent of the reference or control that the assay uses: 115%
Compound 4: middle estimate off by 23 percentage points, on the low side; the measured number lies above the stated range.
By their numbers in this assay, from the lowest: compound 3; then compounds 2 and 1 (each within the scatter of the next); then compound 4.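

On this saturated ring carbon, methyl(3-methylbut-2-en-1-yl)amino moves the number beyond the scatter (a number 14 percentage points higher from compound 1 to compound 4 (beyond the scatter)), which the earlier exchange to compound 2 did not do (a number 8 percentage points lower from compound 1 to compound 2 (within the scatter)). With the methylamino part kept, 2-methylprop-1-en-1-yl in place of thiophen-3-yl on the saturated chain carbon also gives a rise (a number 22 percentage points higher from compound 2 to compound 4 (beyond the scatter)), so a group with no ring can reach the top number in this small set. No evidence at hand accounts for this rise.

Whether the double bond matters remains open, since a saturated 3-methylbutyl group on the same amine is not among these compounds.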